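This account rests on a few compounds, and the source may have more. Where it says the series, first, only, none or still open, it means among the compounds named here.

Compound 1 `NS(=O)(=O)c1ccc(/N=C/c2c(Cl)c3ccccc3oc2=O)cc1` and compound 2 `CC(C)(C)c1cc(C(C)(C)C)c2oc(=O)c(/C=N/c3ccc(S(N)(=O)=O)cc3)c(Cl)c2c1` share a core and differ in the substitution on that core. In a functional assay on MCF7 cells (Homo sapiens) for cytotoxicity, read by CCK-8 assay, with a stated time of 48 h (a lower number here means a stronger inhibitor, a higher number a weaker inhibitor), compound 1 gives 120 nM. In this assay, going by the values given here, compound 2 gives 16 nM, the lowest of the two numbers measured so far; the number of compound 1 lies beyond the scatter above it. As these two structures differ in more than one place, only the two values themselves can be set side by side. Compound 3 `Cc1cc(C)nc(NS(=O)(=O)c2ccc(/N=C/c3c(Cl)c4cc(C(C)(C)C)cc(C(C)(C)C)c4oc3=O)cc2)n1` has not yet been measured in this assay. It differs from compound 2 in a single place: 4,6-dimethylpyrimidin-2-yl in place of hydrogen on a sulfonamide nitrogen. Among the compounds with values here, no measured pair in this set shows how such a change on the sulfonamide nitrogen plays out, so there is no step to lean on, and the rest of the molecule of compound 2 is kept. On that basis the step of a 1.9-fold higher number from compound 2 to compound 3 (0.27 log units; within the scatter) is expected to be small, with its direction uncertain and a slight lean toward a higher number. For compound 3 the estimate in this assay is 30 nM, within a range from 8 nM to 120 nM.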

Compound 3, half-maximal inhibitory concentration: 8.8 nM
Beside the measured number, compound 3's estimate is 3.4-fold (0.53 log units) above it; the range from low to high includes it.
By their numbers in this assay, from the lowest: compounds 3 and 2 (each within the scatter of the next); then compound 1.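

Placing 4,6-dimethylpyrimidin-2-yl in place of hydrogen on a sulfonamide nitrogen gives, in this assay, a 1.8-fold lower number from compound 2 to compound 3 (0.26 log units; within the scatter), the first step read at this position, and it stays within the scatter. In this pair, then, the hydrogen on that nitrogen is not needed for a value of this order, and a substituent with a six-membered aromatic ring and 8 heavy atoms can stand there without a difference that the measurements can separate from the scatter. Nothing in the data shown accounts for this result.

As far as these compounds go, this rests on a single pair and a single group, so it remains open whether a smaller group such as methyl or acetyl, a plain pyridin-2-yl ring, or a short chain ending in a carboxylic acid on the same nitrogen would also stay within the scatter of compound 2. From the compounds shown here alone, it also remains open whether the two methyl groups on the incoming ring matter, and whether the same exchange on compound 1, with its differently substituted core, would give a step of similar size.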